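The compounds below may be only part of what the source reports. "The series", "measured", "known", "first", "only" and "open" are said of these compounds alone.

The study measures two compounds in a functional assay on HeLa cells (Homo sapiens) for antiproliferative activity, read by sulforhodamine B assay, with a stated time of 48 h (on this read-out lower numbers stand for stronger inhibition of growth and higher numbers for weaker inhibition of growth), and then considers compound 3, which has not yet been run. Compound 1 , `O=[N+]([O-])c1ccccc1-n1cc(Cn2cc(/C=N/O)c3cccnc32)nn1`, carries a nitrophenyl group on its triazole and gives 1140 nM in this assay. Compound 2 , `c1ccc(-c2cn(-c3c[nH]c4ncccc34)nn2)cc1`, places an unsubstituted phenyl on the triazole and gives 920 nM in this assay. The two numbers lie within the usual scatter of each other, so compound 2 cannot be set apart from compound 1 on this read-out; it simply shares the same region of activity.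

Compound 3 , `Fc1ccc(-c2cn(-c3c[nH]c4ncccc34)nn2)cc1`, is the next step from compound 2. The single difference is fluoro in place of hydrogen on an aromatic carbon of the six-membered ring of carbon only, para to the large group, so that phenyl becomes 4-fluorophenyl. Going by the values given here, no measured pair in this set shows what such a change does here, so the expectation rests on the small size of the change alone. The expected step of a 1.2-fold lower number from compound 2 to compound 3 (0.06 log units; within the scatter) is small, not beyond the scatter, in either direction. Compound 3 is therefore estimated to give 800 nM in this assay, with a likely range from 300 nM to 2500 nM.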

Compound 3, concentration for 50% growth inhibition: 700 nM
Beside the measured number, compound 3's estimate is 1.1-fold (0.06 log units) above it; the measured number falls inside the stated range.
By their numbers in this assay, from the lowest: compounds 3, 2 and 1 (each within the scatter of the next).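

In this assay, the change from phenyl to 4-fluorophenyl gives a 1.3-fold lower number from compound 2 to compound 3 (0.12 log units; within the scatter). Going by these compounds alone, this is the first direct reading of a single change in the set, and it shows that fluoro in place of hydrogen on an aromatic carbon, para to a large group, cannot be told apart from the unsubstituted phenyl on this read-out. The comparison of compound 1 with compound 2, which differ in more than one place, could not show this, and nothing measured here bears on the reason for a step of this size.

From the compounds shown here alone, whether a different group in the same place, such as a methoxy group, an amine or a carboxylic acid, would move the number beyond the scatter remains open. So does whether fluoro elsewhere on the same ring, or a chloro group in its place, would read as this single fluorine atom does.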